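The compounds below may be only part of what the source reports. "The series", "measured", "known", "first", "only" and "open" are said of these compounds alone.

Measured so far in a functional assay on L1210 cells (Mus musculus) for antiproliferative activity, read by MTT assay, with a stated time of 2 days; a lower number here means a stronger inhibitor, a higher number a weaker inhibitor:

- compound 1 `CCCCCCCCC#Cc1cn(C/C=C\CN2C(=O)c3ccccc3C2=O)c(=O)[nH]c1=O` gives 45000 nM
- compound 2 `CCCCCC#Cc1cn(C/C=C/CN2C(=O)c3ccccc3C2=O)c(=O)[nH]c1=O` gives > 500000 nM, which is a limit of the assay and not a number
- compound 3 `CCCCCc1ccc(C#Cc2cn(C/C=C/CN3C(=O)c4ccccc4C3=O)c(=O)[nH]c2=O)cc1` gives 39000 nM

Compound 1 holds the highest of the two numbers shown in this assay; its nearest neighbour is compound 3, and the gap between them lies within the scatter, so no order between the two can be read. The third value, that of compound 2, sits at the limit of > 500000 nM in this assay, at which 1 of the 3 values shown sits.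

The unmeasured compound 4 `CCCCc1ccc(C#Cc2cn(C/C=C\CN3C(=O)c4ccccc4C3=O)c(=O)[nH]c2=O)cc1` arises from compound 1 by the change (4-butylphenyl in place of octyl on a triple-bonded carbon). Going by the values given here, the one measured step that bears on it is the arylation of the alkyne chain in the pair with the other alkene geometry: an at least 12-fold lower number from compound 2 to compound 3 (1.10 log units; beyond the scatter). Since compound 2 starts from a limit, only the floor of that step is known. Compound 1, though, already sits where compound 3 does, so the change is expected to give a step of moderate size at most, in the direction of a lower number, a 2.3-fold lower number from compound 1 to compound 4 (0.35 log units; beyond the scatter).

Compound 4 is therefore estimated at 20000 nM in this assay, with a range from 6000 nM to 60000 nM.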

Compound 4, half-maximal inhibitory concentration: 31000 nM
Compound 4: the middle estimate sits 1.6-fold (0.19 log units) below what was measured, and the stated range covers the measured number.
By their numbers in this assay, from the lowest: compounds 4, 3 and 1 (each within the scatter of the next). At a limit, above all of these: compound 2.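

In this assay, 4-butylphenyl in place of octyl on a triple-bonded carbon gives a 1.5-fold lower number from compound 1 to compound 4 (0.16 log units; within the scatter), a step that stays within the scatter, so these two groups cannot be told apart at this position. The earlier large step, an at least 12-fold lower number from compound 2 to compound 3 (1.10 log units; beyond the scatter), therefore does not carry over as a general effect of the aromatic ring: it holds for 4-pentylphenyl in place of pentyl, and it does not appear when octyl is the group replaced, in the pair with the other alkene geometry. The size of that earlier step remains only a floor, since compound 2 stands at a limit of the assay and not at a number: the limit of > 500000 nM in this assay, at which 1 of the 4 values shown sits.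

The compounds shown do not separate the effect of alkene geometry from that of the group on the triple-bonded carbon, since no pair among them differs in geometry alone. On these data alone, it also remains open how the number responds to an amine or a carboxylic acid in place of octyl at this position, or to a chain longer than octyl.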